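Fused dithiole nitrile series: benzyl to phenyl on ring nitrogen

The compounds below may be only part of what the source reports. "The series", "measured", "known", "first", "only" and "open" are said of these compounds alone.

Measured compounds:
compound 1 `FC(F)(F)Oc1ccc(/N=c2\ssnc2Cl)cc1Br`: > 100000 nM (a limit)
compound 2 `O=S(=O)(Nc1ncccn1)c1ccc(/N=c2\ssnc2Cl)cc1`: 37000 nM
compound 3 `N#CC1=Nc2c(c(-c3ccccc3)nn2Cc2ccccc2)SS1`: > 100000 nM (a limit)

In a functional assay on PANC-1 cells (Homo sapiens) for cytotoxicity, read by resazurin assay, with a stated time of 72 h (on this read-out higher numbers stand for weaker inhibition and lower numbers for stronger inhibition), compound 1 gives only a limit, > 100000 nM. Compound 2 gives a number, 37000 nM. Compound 3 likewise gives only a limit, > 100000 nM, so its place among the numbers is fixed only by the limit of > 100000 nM in this assay, at which 2 of the 3 values shown sit; the standing of compound 3 against compound 2 cannot be told further than that.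

Compound 4 `N#CC1=Nc2c(c(-c3ccccc3)nn2-c2ccccc2)SS1` differs from compound 3 by phenyl in place of benzyl on an aromatic nitrogen. Within the data shown here, no measured pair shows such a change, so no direction is set; the expectation is no step beyond the scatter in this assay, with a limit again the most likely outcome. Compound 4 is estimated at 100000 nM, between 30000 nM and 300000 nM, a step of a number no higher from compound 3 to compound 4 (the limit leaves the size open).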

Compound 4, half-maximal inhibitory concentration: 75000 nM
Compound 4: the middle estimate sits 1.3-fold (0.12 log units) above what was measured; measured number inside the range.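

In this assay compound 4 gives 75000 nM as a number rather than a limit, the first number for this nitrile core among the compounds shown. The series shows an at least 1.3-fold lower number from compound 3 to compound 4 (0.12 log units; that floor lies within the scatter) with phenyl in place of benzyl on an aromatic nitrogen. As far as these compounds go, the true size of that step stays open, since compound 3 gives only a limit: the limit of > 100000 nM in this assay, at which 2 of the 4 values shown sit.

Still open, from the compounds shown here alone, is how a longer chain on this aromatic nitrogen would read here. Equally open, going by these compounds, is the effect of an amine or a carboxylic acid on the phenyl ring there.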